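This account rests on a few compounds, and the source may have more. Where it says the series, first, only, none or still open, it means among the compounds named here.

In a physicochemical assay for lipophilicity, read by HPLC, measured as chromatographic lipophilicity, at pH 7.4 (on this read-out lower numbers stand for lower lipophilicity and higher numbers for higher lipophilicity), compound 1 (`O=C(c1cccnc1)N1N=CCC1c1ccccc1`) gives 2.7. Going by the values given here, the only other measured member of the series, compound 2 (`CC(C)(C)C(=O)N1N=CCC1c1cocn1`), gives 3. These two numbers lie within the usual scatter of each other, so compound 1 has no clearly separate place on this scale. Among the compounds with values here, the pair differs in more than one place and offers no measured step to lean on.

Compound 3 (`O=C(c1ccccn1)N1N=CCC1c1ccccc1`) carries pyridin-2-yl in place of pyridin-3-yl on a carbonyl carbon. Compounds 1 and 3 have the same atoms, joined differently. Within the data shown here, with no measured precedent for this exchange, the change expected in this assay is small, upward if anything, and not beyond the scatter. The expected size is a number 0.20 log units higher from compound 1 to compound 3 (within the scatter). The estimate for compound 3 is 2.9, with an expected range from 2.4 to 3.4.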

Compound 3, distribution coefficient: 2.4
Estimate against measurement, compound 3: 0.50 log units above; measured number inside the range.
By their numbers in this assay, from the lowest: compounds 3, 1 and 2 (each within the scatter of the next, the first and the last beyond it).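

Going by these compounds alone, on a carbonyl carbon, pyridin-2-yl in place of pyridin-3-yl is the first single-place step, and in this assay it reads a number 0.30 log units lower from compound 1 to compound 3 (within the scatter) with the same atoms joined differently. This exchange therefore does not separate the pair on this scale, and this position shows no clear shift for this change. Nothing at hand gives a reason for the step.

Still open, going by these compounds, is how pyridin-4-yl on the same carbonyl carbon would read in this assay against compound 1 and compound 3. Also open is whether a group of another kind there, such as a carboxylic acid or an aliphatic amine, would give a step beyond the scatter, which the compounds shown cannot indicate.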